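The source may hold more compounds than are shown below. What is called first, only, known or untested is meant among the compounds shown, and "the series" means these compounds.

Measured in an in vitro ADME assay on microsomes (Mus musculus) for metabolic stability; on this read-out lower numbers stand for a shorter-lived compound and higher numbers for a longer-lived compound:
- Compound 1 `CNC(=O)Nc1ccc(-c2nc(N3CC4CCC(C3)O4)c3cnn(C(C)C)c3n2)cc1`: > 0.5 h (a limit)
- Compound 2 `CNC(=O)Nc1ccc(-c2nc(N3CC4CCC(C3)O4)c3cnn(C)c3n2)cc1`: > 0.5 h (a limit)
- Compound 3 `CNC(=O)Nc1ccc(-c2nc(N3CC4CCC(C3)O4)c3cnn(C4CCC5(CC4)OCCCO5)c3n2)cc1`: > 0.5 h (a limit)

Compound 3 has no exact number in this assay. Its result is a limit, and the two other measured compounds are also known only as limits, so the series gives no ranking. The evidence amounts to one line: the limit of > 0.5 h in this assay, at which 3 of the 3 values shown sit.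

Compound 4 `CNC(=O)Nc1ccc(-c2nc(N3CC4CCC(C3)O4)c3cnn([C@H]4CC[C@H](OC)CC4)c3n2)cc1` is still to be measured. The change leading to it is a group of 8 heavy atoms (7 carbon, 1 oxygen; one six-membered non-aromatic ring of carbon only) in place of a group of 11 heavy atoms (9 carbon, 2 oxygen; one six-membered non-aromatic ring of carbon only, one six-membered non-aromatic ring with 2 hetero atoms), on an aromatic nitrogen. In words, 4-methoxycyclohexyl enters on an aromatic nitrogen of a five-membered aromatic ring with 2 nitrogen, part of a fused or bridged system of two rings.

Among the compounds with values here, two measured steps bear most directly on this position: a step that the two limits leave unreadable from compound 1 to compound 3 and a step that the two limits leave unreadable from compound 2 to compound 3. A third, a step that the two limits leave unreadable from compound 1 to compound 2, changes the same nitrogen substituent. None has a readable size, so they give no direction for the new change. Even so, three different groups at this nitrogen all reached the same limit, so no step beyond the usual scatter is expected, in either direction. The estimated step is a step that the limit leaves unreadable from compound 3 to compound 4. For compound 4 the expected value is 0.6 h, with an estimated range from 0.3 h to 1.2 h.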

Compound 4, half-life: > 0.5 h
Compound 4 was reported as a limit (the forecaster's own chance of this, stated with the estimate: 70%); the middle value is on the limit's open side.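

In this assay compound 4 gives > 0.5 h, which is a limit. Within the data shown here, no step from compound 1, compound 2 or compound 3 to compound 4 can therefore be read. The compounds shown leave open how long each one actually lasts and whether the group on the aromatic nitrogen changes that at all: the limit of > 0.5 h in this assay, at which 4 of the 4 values shown sit.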